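The compounds below may be only part of what the source reports. "The series", "measured", "known", "first", "only" and "open" are said of these compounds alone.

Two measured compounds share the same core. Compound 1 `C=CCn1c(=O)/c(=C\c2ccccc2Cl)[nH]c(=O)/c1=C\c1ccccc1OC` gives 4700 nM in a functional assay on MCF7 cells (Homo sapiens) for cytotoxicity, read by CCK-8 assay, with a stated time of 72 h (a higher number here means a weaker inhibitor, a lower number a stronger inhibitor), and compound 2 `C=CCn1c(=O)/c(=C\c2ccccc2C(F)(F)F)[nH]c(=O)/c1=C\c1ccccc1OC` gives 6500 nM in this assay. Within the data shown here, the only measured step, a 1.4-fold higher number from compound 1 to compound 2 (0.14 log units; within the scatter), is a small one, so compound 2 and compound 1 cannot be ranked against each other on these numbers; compound 2 simply holds the higher of the two values.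

Compound 3 `C=CCn1c(=O)/c(=C\c2ccc(F)c(Br)c2)[nH]c(=O)/c1=C\c1ccccc1OC` differs from compound 2 in one place: 3-bromo-4-fluorophenyl in place of 2-(trifluoromethyl)phenyl on a double-bonded chain carbon bound to an aromatic carbon. Among the measured compounds shown here, no measured step bears on this change. For the measured compounds named here, the single step available, a 1.4-fold higher number from compound 1 to compound 2 (0.14 log units; within the scatter), only shows that one exchange of a substituent on that ring left the number within the scatter, and it does not cover the exchange made here. On that slim basis, compound 3 is expected to give a value close to that of compound 2, the estimated step being a 1.1-fold lower number from compound 2 to compound 3 (0.03 log units; within the scatter). The estimate for compound 3 in this assay is 6000 nM, within a range from 2000 nM to 18000 nM.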

Compound 3, half-maximal inhibitory concentration: "not active" (no number reported)
No number was reported for compound 3, so the estimate cannot be set against anything.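

Among these compounds, compound 3 is reported as "not active" in this assay with no number, so no step from compound 2 to compound 3 can be read. No measurement shown here explains this result. The compounds shown leave open how far 3-bromo-4-fluorophenyl in place of 2-(trifluoromethyl)phenyl shifts the value.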